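Replacing the chlorophenyl with an isoquinoline on the sulfonyl

The source may report more compounds than this note shows. Statements on the series, on what has been measured and on what is new or still open speak of the compounds shown alone.

Of the compounds shown here, three built on one shared core have been measured in an assay on isolated protein for inhibition of B1 bradykinin receptor (Homo sapiens); on this read-out lower numbers stand for stronger inhibition and higher numbers for weaker inhibition. Compound 1 `CC(C)(C)NCc1ccc2c(c1)CCC[C@H]2NC(=O)C[C@@H]1CCCCN1S(=O)(=O)c1ccccc1` carries a plain phenyl on the sulfonyl sulfur and gives 1700 nM. Compound 2 `COc1ccc(S(=O)(=O)N2CCCC[C@H]2CC(=O)N[C@@H]2CCCc3cc(CNC(C)(C)C)ccc32)cc1` adds a methoxy group to that ring and gives 780 nM, and compound 3 `CC(C)(C)NCc1ccc2c(c1)CCC[C@H]2NC(=O)C[C@@H]1CCCCN1S(=O)(=O)c1cccc(Cl)c1` carries a chloro group instead and gives 120 nM. Compound 3 stands lowest of the three numbers; the steps are a 2.2-fold lower number from compound 1 to compound 2 (0.34 log units; beyond the scatter), a 14-fold lower number from compound 1 to compound 3 (1.15 log units; beyond the scatter) and a 6.5-fold lower number from compound 2 to compound 3 (0.81 log units; beyond the scatter).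

Compound 4 `CC(C)(C)NCc1ccc2c(c1)CCC[C@H]2NC(=O)C[C@@H]1CCCCN1S(=O)(=O)c1cccc2cnccc12` changes the same position again, this time as isoquinolin-5-yl in place of 3-chlorophenyl on a sulfonyl sulfur. All three measured steps concern the ring on the sulfonyl sulfur, and they show that this part of the molecule moves the number by modest to large amounts in either direction. Going by the values given here, none of them involves a fused two-ring system, so there is no direct precedent for compound 4. The bicyclic group differs more from compound 3 than the other changes did, and the measured steps give no footing for a firm direction. The step from compound 3 to compound 4 is expected to be small in size but rather uncertain in direction, a 3.3-fold higher number from compound 3 to compound 4 (0.52 log units; beyond the scatter). Compound 4 is expected to give about 400 nM in this assay, within the range 80 nM to 2000 nM.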

Compound 4, half-maximal inhibitory concentration: 610 nM
Compound 4: middle estimate off by 1.5-fold (0.18 log units), on the low side; measured number inside the range.
By their numbers in this assay, from the lowest: compound 3; then compounds 4 and 2 (each within the scatter of the next); then compound 1.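

Isoquinolin-5-yl is the first fused two-ring group seen on the sulfonyl sulfur, and in this assay it gives up part of what the chloro group gained (a 5.1-fold higher number from compound 3 to compound 4 (0.71 log units; beyond the scatter)) while still keeping a gain over the plain phenyl (a 2.8-fold lower number from compound 1 to compound 4 (0.45 log units; beyond the scatter)). Set against the 4-methoxyphenyl group, it shows no real difference (a 1.3-fold lower number from compound 2 to compound 4 (0.11 log units; within the scatter)): this step lies within the scatter, so two quite different groups read alike here. The position therefore accepts a second fused ring containing a nitrogen with no loss against plain phenyl, but this group does not match 3-chlorophenyl, and no information at hand accounts for the size of these steps.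

The compounds shown leave open whether the rise from compound 3 to compound 4 follows the loss of the chloro group, the added second ring or the ring nitrogen, since all three change in this one step. A naphthyl group, which has two fused rings and no ring nitrogen, or an isoquinoline carrying a chloro group would help to separate these parts.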